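Chain length in the ester tail and cytotoxicity

A few compounds are considered here, and "the series" means these few. Any claim that something is new, unique, unknown or untested is made for them only; others in the source may bear on it.

The shared core of compound 3 `CCCCCCCCCOC(=O)CCC(=O)N1CCN(CCCOc2cc3c(Nc4ccc(F)c(Cl)c4)ncnc3cc2OC)CC1` carries a nonyl ester; in a functional assay on A549 cells (Homo sapiens) for cytotoxicity, read by MTT assay, with a stated time of 24 h, tested at 80 uM (on this read-out higher numbers stand for a weaker effect at the one concentration tested and lower numbers for a stronger effect), compound 3 gives 7.8%, the lowest of the three numbers. Compound 1 `CCCCCOC(=O)CCC(=O)N1CCN(CCCOc2cc3c(Nc4ccc(F)c(Cl)c4)ncnc3cc2OC)CC1` gives 18.2% and compound 2 `CCCCCCCOC(=O)CCC(=O)N1CCN(CCCOc2cc3c(Nc4ccc(F)c(Cl)c4)ncnc3cc2OC)CC1` gives 27.2%. Compound 4 `CCCCCCCCCCCCCCOC(=O)CCC(=O)N1CCN(CCCOc2cc3c(Nc4ccc(F)c(Cl)c4)ncnc3cc2OC)CC1` differs from compound 3 by pentyl in place of hydrogen on a saturated chain carbon, nine bonds along the chain from an oxygen next to a carbonyl group. Among the measured compounds shown here, the steps that bear on this extension are a number 10.4 percentage points lower from compound 1 to compound 3 (beyond the scatter) and a number 19.4 percentage points lower from compound 2 to compound 3 (beyond the scatter), both modest and beyond the scatter, while a number 9 percentage points higher from compound 1 to compound 2 (within the scatter) stayed within it. Extending the chain has so far given no rise beyond scatter, and compound 3 already sits close to the floor of the read-out, so the expected step is a number 2.8 percentage points lower from compound 3 to compound 4 (within the scatter), small. Compound 4 is therefore expected at 5%, within 0% to 16%.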

Compound 4, a percentage reported as activity, at one concentration (the size of the read-out at that concentration, not a potency): 77.2%
For compound 4 the middle estimate is 72.2 percentage points below the measured one, outside the stated range (above it).
By their numbers in this assay, from the lowest: compound 3; then compounds 1 and 2 (each within the scatter of the next); then compound 4.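

At the chain carbon nine bonds along the chain from an oxygen next to a carbonyl group, pentyl in place of hydrogen reverses the trend in this assay: the step is a number 69.4 percentage points higher from compound 3 to compound 4 (beyond the scatter) and marks a much weaker effect, whereas no earlier lengthening gave a rise beyond the scatter. The same long chain also stands apart from the two shorter esters, with a number 50 percentage points higher from compound 2 to compound 4 (beyond the scatter) and a number 59 percentage points higher from compound 1 to compound 4 (beyond the scatter) as its steps. Chain length therefore gives no steady trend across the four compounds, and compound 3 goes against any steady rise.

Where between the nonyl ester and compound 4 the change sets in remains open, as does the effect of a longer chain or of a carboxylic acid or an amine in place of the pentyl. No measurement shown accounts for the reversal.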